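Methoxy in place of hydrogen on compound 2

A few compounds are considered here, and "the series" means these few. Any claim that something is new, unique, unknown or untested is made for them only; others in the source may bear on it.

Compound 2 (`C=C[C@@](C)(/C=C/c1ccc(Nc2ccc(OC)cc2)cc1)CCC=C(C)C`) stands at > 36600 nM in an ADME assay on HEK293 cells (Homo sapiens) for cytotoxicity, with a stated time of 72 h (on this read-out higher numbers stand for an effect only at larger amounts of compound and lower numbers for an effect already at smaller amounts), and that is a limit, not a number. Compound 1 (`C=C[C@@](C)(/C=C/c1ccc(OS(=O)(=O)C(F)(F)F)cc1)CCC=C(C)C`) gives > 36600 nM as a limit too. Going by the values given here, the only measured step (a step that the two limits leave unreadable from compound 1 to compound 2) has no readable size, and both values are the same limit (the limit of > 36600 nM in this assay, at which 2 of the 2 values shown sit). Compound 3 (`C=C[C@@](C)(/C=C/c1ccc(Nc2ccc(OC)c(OC)c2)cc1)CCC=C(C)C`) carries one change (methoxy in place of hydrogen on an aromatic carbon): methoxy in place of hydrogen on an aromatic carbon, ortho to a methoxy group. No step beyond the scatter is expected in this assay for this change. The estimated step (a step that the limit leaves unreadable from compound 2 to compound 3) reflects that expectation. Compound 3 is estimated at 40000 nM (range 15000 nM to 90000 nM) and may again be reported as a limit.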

Compound 3, half-maximal effective concentration: > 36600 nM
Compound 3 gave a limit, no number (the forecaster's own chance of this, stated with the estimate: 75%); the middle value is on the limit's open side.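

No step can be read from compound 2 to compound 3, because both values are limits, not numbers: the limit of > 36600 nM in this assay, at which 3 of the 3 values shown sit.

The compounds shown leave open whether compound 1, compound 2 and compound 3 differ at all.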